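A few compounds are considered here, and "the series" means these few. Any claim that something is new, unique, unknown or untested is made for them only; others in the source may bear on it.

Compound 1 `Cc1cc(/C=C/c2ccc(O)cc2)[nH]n1`: 23200 nM
Compound 2 `Cc1cc(/C=C/c2ccc(O)c(O)c2)on1`: 8900 nM

Going by the values given here, these are the only two values so far in a functional assay on MDA-MB-231 cells (Homo sapiens) for cytotoxicity, read by MTT assay, with a stated time of 72 h; on this read-out lower numbers stand for stronger inhibition and higher numbers for weaker inhibition. Compound 2 has the lower number of the pair, and compound 1 lies higher by more than the usual scatter of repeated measurements. Compound 3 `COc1cc(/C=C/c2cc(C)no2)ccc1O` has not yet been measured. It differs from compound 2 by one change: methyl in place of hydrogen on an oxygen on an aromatic ring, which also reads as hydroxy to methoxy. Among the compounds with values here, no pair of measured compounds shows this kind of change, so the expectation in this assay is only a cautious judgement: a small move to a higher number, meaning somewhat weaker inhibition. The estimated change is a 1.7-fold higher number from compound 2 to compound 3 (0.23 log units; within the scatter). For compound 3 the estimated value is 15000 nM, with an expected range of 6000 nM to 35000 nM.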

Compound 3, half-maximal inhibitory concentration: 34600 nM
The estimate for compound 3 lay 2.3-fold (0.36 log units) below the measured number; low and high end bracket the measured number.
By their numbers in this assay, from the lowest: compound 2; then compounds 1 and 3 (each within the scatter of the next).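

In this assay, replacing hydrogen with methyl on an oxygen on an aromatic ring gives a 3.9-fold higher number from compound 2 to compound 3 (0.59 log units; beyond the scatter) and so weakens inhibition by more than the scatter. Going by these compounds alone, compound 1 and compound 2 differ in more than one place, so they could not isolate this oxygen; this single step is the first direct reading of it, and it shows that the hydroxy group cannot be turned into methoxy here without a loss. Within the data shown here, nothing measured so far explains why the number rises.

The compounds shown leave open whether the loss grows with size, as an ethyl group or a longer chain on the same oxygen would show. They also leave open how an amine or a fluorine atom in place of this hydroxy group would compare, and one step cannot say whether the same change would act alike on another core.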